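Allyl to 2-methylbenzyl on the ring amine

The compounds below may be only part of what the source reports. "The series", "measured", "known", "first", "only" and "open" are said of these compounds alone.

Compound 1 `CCCN1CCC(c2noc(COc3ccc(/C=C/C(=O)NO)cc3)n2)CC1` gives 69% in an assay on isolated protein for inhibition of protein deacetylase HDAC6 (Homo sapiens), read by fluorescence, with a stated time of 1 h, tested at 100 nM; on this read-out lower numbers stand for less inhibition and higher numbers for more inhibition at the one concentration tested (going by the name of the read-out).
Compound 2 `C=CCN1CCC(c2noc(COc3ccc(/C=C/C(=O)NO)cc3)n2)CC1` gives 66% in this assay.
Compound 3 `O=C(/C=C/c1ccc(OCc2nc(C3CCN(Cc4ccccc4)CC3)no2)cc1)NO` gives 71% in this assay.

All three share one core and differ only in the group on a saturated chain carbon bound to an amine nitrogen in a ring. Compound 2 has the lowest number of the three, yet a number 3 percentage points lower from compound 1 to compound 2 (within the scatter) and a number 5 percentage points higher from compound 2 to compound 3 (within the scatter) both lie within the scatter, so no real ordering can be read from them. Compound 4 `Cc1ccccc1CN1CCC(c2noc(COc3ccc(/C=C/C(=O)NO)cc3)n2)CC1` carries 2-methylphenyl in place of vinyl on a saturated chain carbon bound to an amine nitrogen in a ring. The closest measured steps are a number 5 percentage points higher from compound 2 to compound 3 (within the scatter), where a phenyl replaced the same vinyl, and a number 2 percentage points higher from compound 1 to compound 3 (within the scatter); neither moved the number beyond the scatter. No shift beyond the scatter is therefore expected here: compound 4 is estimated at 70%, between 58% and 82%, meaning an expected step of a number 4 percentage points higher from compound 2 to compound 4 (within the scatter).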

Compound 4, a percentage reported as inhibition, at one concentration (the size of the read-out at that concentration, not a potency): 68%
Beside the measured number, compound 4's estimate is 2 percentage points above it; the measured number falls inside the stated range.
By their numbers in this assay, from the lowest: compounds 2, 4, 1 and 3 (each within the scatter of the next).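

In this assay, replacing vinyl (2 heavy atoms) with 2-methylphenyl (7 heavy atoms) gives a number 2 percentage points higher from compound 2 to compound 4 (within the scatter), and replacing ethyl with it gives a number 1 percentage points lower from compound 1 to compound 4 (within the scatter), so this larger, substituted aromatic group still leaves the number within the scatter of the smaller groups. Adding a methyl to the aromatic ring gives a number 3 percentage points lower from compound 3 to compound 4 (within the scatter), so this added methyl has no readable effect here. No evidence is available to explain these numbers.

Going by these compounds, whether a group carrying an amine or a carboxylic acid at this position would move the number remains open. So does the effect of a longer chain between the ring amine and the aromatic ring.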